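The source may hold more compounds than are shown below. What is called first, only, known or untested is meant among the compounds shown, and "the series" means these compounds.

Of the compounds shown here, three built on one shared core have so far been measured in a functional assay on MDA-MB-231 cells (Homo sapiens) for inhibition, read by sulforhodamine B assay, tested at 10 uM; a lower number here means less inhibition, a higher number more inhibition at the concentration tested (going by the name of the read-out). Compound 1 `COC(=O)CC(=O)N1N=C(c2ccc(N3CCN(C)CC3)cc2)CC1c1ccc(N(C)C)cc1` carries a ((methoxycarbonyl)methyl)carbonyl group on an amine nitrogen in a ring and gives -0.4% in this assay. Compound 2 `Cc1ccc(C(=O)N2N=C(c3ccc(N4CCN(C)CC4)cc3)CC2c2ccc(N(C)C)cc2)cc1` gives -0.7%, and compound 3 `CN1CCN(c2ccc(C3=NN(S(=O)(=O)c4ccc(F)cc4)C(c4ccc(N(C)C)cc4)C3)cc2)CC1` gives 15.7%. Compound 1 therefore stands second highest of the three numbers, with compound 2 closest to it: a number 0.3 percentage points lower from compound 1 to compound 2 (within the scatter). The only sizeable move among the measured compounds is a number 16.1 percentage points higher from compound 1 to compound 3 (beyond the scatter), and in the same way a number 16.4 percentage points higher from compound 2 to compound 3 (beyond the scatter).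

Compound 4 `CN1CCN(c2ccc(C3=NN(S(=O)(=O)c4ccc(Br)cc4)C(c4ccc(N(C)C)cc4)C3)cc2)CC1` has not yet been measured. Set against compound 1 it differs in one place: (4-bromophenyl)sulfonyl in place of ((methoxycarbonyl)methyl)carbonyl on an amine nitrogen in a ring. The measured step that bears most directly on this is a number 16.1 percentage points higher from compound 1 to compound 3 (beyond the scatter), where a (4-fluorophenyl)sulfonyl group took the place of the same ((methoxycarbonyl)methyl)carbonyl group on the same nitrogen and lifted inhibition by a modest but real amount. Compound 4 carries the closely related (4-bromophenyl)sulfonyl group, so a step of similar size and in the same direction is expected, a number 17.4 percentage points higher from compound 1 to compound 4 (beyond the scatter). Among the compounds with values here, nothing among the measured compounds shows how bromine rather than fluorine on that ring shifts the read-out, so the range is kept wide. Compound 4 is therefore estimated to give 17%, within a range from 5% to 30%.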

Compound 4, a percentage reported as inhibition, at one concentration (the size of the read-out at that concentration, not a potency): 23.7%
The estimate for compound 4 lay 6.7 percentage points below the measured number; low and high end bracket the measured number.
By their numbers in this assay, from the lowest: compounds 2 and 1 (each within the scatter of the next); then compounds 3 and 4 (each within the scatter of the next).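

With the second sulfonyl compound, the rise in this assay no longer rests on a single compound: a number 24.1 percentage points higher from compound 1 to compound 4 (beyond the scatter) and a number 24.4 percentage points higher from compound 2 to compound 4 (beyond the scatter) both lie beyond the usual scatter, so both sulfonyl compounds stand apart from the two carbonyl-linked ones at this amine nitrogen in a ring. Exchanging the halogen on the aromatic ring does not separate the two sulfonyl compounds, as a number 8 percentage points higher from compound 3 to compound 4 (within the scatter) stays within the scatter, and fluoro and bromo cannot be told apart in this read-out. Among these four compounds, the higher inhibition therefore goes with the halogen-bearing phenylsulfonyl groups as a pair, although nothing available explains why these groups give more inhibition than the carbonyl-linked ones.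

The compounds shown leave open whether the sulfonyl link or its aromatic ring matters more, a question that a methylsulfonyl group in the same place could help answer. They also leave open whether a chloro, methoxy or amino group on that aromatic ring would keep inhibition at this level, or whether the halogen matters at all.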